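Methoxy to trifluoromethoxy on a fixed core

This account rests on a few compounds, and the source may have more. Where it says the series, first, only, none or still open, it means among the compounds named here.

Compound 1, `CN(Cc1nc2cc(C(F)(F)F)ccc2nc1-c1ccccc1)c1ccc(OC(F)(F)F)cc1`, gives 3000 nM in an assay on isolated protein for inhibition of Dihydrofolate reductase (Homo sapiens), read by spectrophotometry; a higher number here means a weaker inhibitor, a lower number a stronger inhibitor.
Compound 2, `C#CCN(Cc1nc2cc(C(F)(F)F)ccc2nc1-c1ccccc1)c1ccc(Cl)cc1`, gives 4000 nM.
Compound 3, `C#CCN(Cc1nc2cc(C(F)(F)F)ccc2nc1-c1ccccc1)c1ccc(OC)cc1`, gives 3000 nM.

Compound 3 stands level with compound 1 at the digits shown, and together they hold the lowest numbers of the three; the only step linking compound 3 to another measured compound is a 1.3-fold lower number from compound 2 to compound 3 (0.12 log units; within the scatter), within the scatter. Compound 4, `C#CCN(Cc1nc2cc(C(F)(F)F)ccc2nc1-c1ccccc1)c1ccc(OC(F)(F)F)cc1`, differs from compound 3 by trifluoromethyl in place of methyl on an oxygen on an aromatic ring. Among the measured compounds shown here, no measured step covers this exact change; compound 1 carries the same trifluoromethoxy group beside a different substituent on the nitrogen, and its value is level with that of compound 3. Compound 4 is therefore expected to show no change at the digits printed from compound 3 to compound 4 (within the scatter), nothing beyond the scatter. Compound 4 is estimated at 3000 nM, between 1500 nM and 6000 nM.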

Compound 4, inhibition constant: 4000 nM
Beside the measured number, compound 4's estimate is 1.3-fold (0.12 log units) below it, within the range that was stated.
By their numbers in this assay, from the lowest: compounds 1, 3, 2 and 4 (each within the scatter of the next).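

In this assay, among the compounds shown here, trifluoromethyl in place of methyl on an oxygen on an aromatic ring gives a 1.3-fold higher number from compound 3 to compound 4 (0.12 log units; within the scatter) and so provides the first direct reading of this change. Trifluoromethoxy in place of chloro on an aromatic carbon gives no change at the digits printed from compound 2 to compound 4 (within the scatter) while ethynyl in place of hydrogen on a saturated chain carbon bound to a nitrogen on an aromatic ring gives a 1.3-fold higher number from compound 1 to compound 4 (0.12 log units; within the scatter) and thus all four compounds remain within the scatter. No available evidence bears on these results.

Still open, going by these compounds, is whether an amine or a carboxylic acid in place of the trifluoromethoxy, or a longer chain in place of the ethynyl, would move the number beyond the scatter.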